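Dimethylamino in place of (2-hydroxyethyl)amino on the shared core

The source may hold more compounds than are shown below. What is called first, only, known or untested is meant among the compounds shown, and "the series" means these compounds.

Compound 2 `OCCNc1[nH]ccc2ncnc1-2` gives 3% in a functional assay (Homo sapiens) for inhibition of Nucleic Acid, tested at 100 uM (on this read-out lower numbers stand for less inhibition and higher numbers for more inhibition at the one concentration tested (going by the name of the read-out)), the lower of the two numbers measured. For the measured compounds named here, its neighbour, compound 1 `Sc1[nH]ccc2ncnc1-2`, gives 26%, and the one measured step, a number 23 percentage points lower from compound 1 to compound 2 (beyond the scatter), accompanies (2-hydroxyethyl)amino in place of sulfanyl on an aromatic carbon. Compound 3 `CN(C)c1[nH]ccc2ncnc1-2` has not been measured; it differs from compound 2 by dimethylamino in place of (2-hydroxyethyl)amino on an aromatic carbon. Going by the values given here, no measured step swaps one amino group for another on this carbon, so the step from compound 1 to compound 2 bears on it only loosely, showing that a change at this position can move the read-out by a modest amount. With nothing pointing to a rise, compound 3 is expected to stay close to compound 2, with an estimated step of a number 7 percentage points higher from compound 2 to compound 3 (within the scatter) in this assay. The estimate for compound 3 is 10%, within the range 0% to 32%.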

Compound 3, a percentage reported as inhibition, at one concentration (the size of the read-out at that concentration, not a potency): 8%
Compound 3: the middle estimate sits 2 percentage points above what was measured; low and high end bracket the measured number.
By their numbers in this assay, from the lowest: compounds 2 and 3 (each within the scatter of the next); then compound 1.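

With a number 5 percentage points higher from compound 2 to compound 3 (within the scatter) in this assay on replacing (2-hydroxyethyl)amino with dimethylamino, the read-out does not separate these two amino groups on this aromatic carbon, even though dimethylamino carries 0 hydrogen-bond donors and the group it replaces carries 2. Dimethylamino in place of sulfanyl gives a number 18 percentage points lower from compound 1 to compound 3 (beyond the scatter), so a second amino group now stands apart from sulfanyl by a step beyond the scatter, and the gap seen earlier is not confined to (2-hydroxyethyl)amino. No evidence is available that explains either step.

On these data alone, what a plain primary amine, a longer chain or a carboxylic acid would give on this carbon remains open. So does whether any group here can carry the read-out past that of compound 1 at 26%.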